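Methoxy to difluoromethoxy in the series

The compounds below may be only part of what the source reports. "The series", "measured", "known", "first", "only" and "open" are said of these compounds alone.

Values in a functional assay on HeLa cells (Homo sapiens) for antiproliferative activity, read by resazurin assay; a higher number here means a weaker inhibitor, a lower number a stronger inhibitor:
- compound 1 `CCSC(=S)SCC(=O)c1ccccc1`: 5010 nM
- compound 2 `CCSC(=S)SCC(=O)c1ccc(C)cc1`: 3980 nM
- compound 3 `CCSC(=S)SCC(=O)c1ccc(OC)cc1`: 2510 nM

Compound 3 lies within the scatter of both compound 1 and compound 2, so these three values give no ranking. The next structure, compound 4 `CCSC(=S)SCC(=O)c1ccc(OC(F)F)cc1`, carries one change from compound 3: difluoromethyl in place of methyl on an oxygen on an aromatic ring. This reads as methoxy to difluoromethoxy. The nearest measured evidence is a 2.0-fold lower number from compound 1 to compound 3 (0.30 log units; within the scatter) and a 1.6-fold lower number from compound 2 to compound 3 (0.20 log units; within the scatter), and neither step leaves the scatter. Among the measured compounds shown here, no measured compound carries fluorine, so the evidence is indirect. No shift beyond the scatter is therefore expected in this assay, and the expected change is a 1.0-fold lower number from compound 3 to compound 4 (0.00 log units; within the scatter). Compound 4 is estimated at 2500 nM, with an expected range of 1200 nM to 5000 nM.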

Compound 4, half-maximal inhibitory concentration: 3980 nM
The estimate for compound 4 lay 1.6-fold (0.20 log units) below the measured number, and the stated range covers the measured number.
By their numbers in this assay, from the lowest: compounds 3, 2, 4 and 1 (each within the scatter of the next).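

Among the compounds shown here, replacing methyl with difluoromethyl on an oxygen on an aromatic ring adds fluorine to the series for the first time, yet in this assay the step remains within the scatter, with a 1.6-fold higher number from compound 3 to compound 4 (0.20 log units; within the scatter). Difluoromethoxy also stays within the scatter of the other two groups, with no change at the digits printed from compound 2 to compound 4 (within the scatter) and a 1.3-fold lower number from compound 1 to compound 4 (0.10 log units; within the scatter), so the four compounds still give no ranking. No available measurement bears on the reason for this result.

Still open, from the compounds shown here alone, is whether an amine or a carboxylic acid in this place would give a step beyond the scatter. Going by these compounds, a longer chain on the oxygen, such as ethyl, also remains open.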